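A few compounds are considered here, and "the series" means these few. Any claim that something is new, unique, unknown or untested is made for them only; others in the source may bear on it.

Working notes, series around a shared core

Three members of the series have been measured in a functional assay on SiHa cells (Homo sapiens) for inhibition, read by CCK-8 assay, with a stated time of 72 h, tested at 10 uM; a lower number here means less inhibition of growth, a higher number more inhibition of growth at the concentration tested. Compound 1 `CN(C)C(=O)c1cc2cnc(Nc3ccc(NC(=O)C4(C(=O)Nc5cccc(O)c5)CC4)cc3)nc2n1C1CCCC1` carries a 3-hydroxyphenyl on the amide-type nitrogen and in this assay compound 1 gives 75.7%. Compound 2 `CN(C)C(=O)c1cc2cnc(Nc3ccc(NC(=O)C4(C(=O)Nc5ccc(Br)cc5)CC4)cc3)nc2n1C1CCCC1`, with a 4-bromophenyl at that nitrogen, gives 98.8% in this assay. Compound 3 `CN(C)C(=O)c1cc2cnc(Nc3ccc(NC(=O)C4(C(=O)Nc5ccc(O)cc5)CC4)cc3)nc2n1C1CCCC1`, with a 4-hydroxyphenyl there, gives 94.3% in this assay; it stands second of the three numbers, within the scatter of compound 2 and beyond the scatter above compound 1.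

Among the compounds with values here, the steps so far: a number 23.1 percentage points higher from compound 1 to compound 2 (beyond the scatter); a number 18.6 percentage points higher from compound 1 to compound 3 (beyond the scatter); a number 4.5 percentage points lower from compound 2 to compound 3 (within the scatter). Two of the three steps are modest, and the one exchanging hydroxy for bromo on the aromatic carbon stays within the scatter.

Compound 4 `CN(C)C(=O)c1cc2cnc(Nc3ccc(NC(=O)C4(C(=O)Nc5cccc(F)c5)CC4)cc3)nc2n1C1CCCC1` is the next member. Its difference from compound 3: 3-fluorophenyl in place of 4-hydroxyphenyl on an amide-type nitrogen. Within the data shown here, the steps that bear on this are the two that move from 3-hydroxyphenyl to a 4-substituted phenyl, each modest and upward; the exchange of a 4-substituent for another is within the scatter. The new compound returns to a 3-substituted phenyl, so a modest downward step in this assay is expected, without a measured step for a 3-fluorophenyl to confirm it. Compound 4 is thus estimated at 82%, with a range from 65% to 97%, meaning an expected step of a number 12.3 percentage points lower from compound 3 to compound 4 (beyond the scatter).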

Compound 4, percent growth inhibition at one concentration: 107%
For compound 4 the middle estimate is 25 percentage points below the measured one, and the stated range ends below it.
By their numbers in this assay, from the lowest: compound 1; then compounds 3, 2 and 4 (each within the scatter of the next, the first and the last beyond it).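

In this assay, a 3-substituted phenyl on the amide-type nitrogen no longer goes with the lowest number, since fluoro in place of hydroxy on an aromatic carbon gives a large step (a number 31.3 percentage points higher from compound 1 to compound 4 (beyond the scatter)), so the low number of compound 1 belongs to the 3-hydroxyphenyl and not to every group with a substituent at that ring position. The 3-fluorophenyl also stands beyond the scatter against the 4-hydroxyphenyl (a number 12.7 percentage points higher from compound 3 to compound 4 (beyond the scatter)) but within it against the 4-bromophenyl (a number 8.2 percentage points higher from compound 2 to compound 4 (within the scatter)), so compound 2 and compound 4 cannot be ordered, and a substituent's ring position alone does not set the number in these four compounds. No measurement shown accounts for the difference between the fluoro and hydroxy groups on this ring.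

Open, on these data alone, is how an unsubstituted phenyl, a 4-fluorophenyl or a 3-bromophenyl would compare, which would separate the effect of the substituent from that of its ring position. Also open, as far as these compounds go, is whether an amine or a carboxylic acid on this phenyl would fall with compound 1 or stand with compound 2, compound 3 and compound 4.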